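The source may hold more compounds than are shown below. What is called first, only, known or untested is meant among the compounds shown, and "the series" means these compounds.

In a functional assay on A549 cells (Homo sapiens) for antiproliferative activity, read by MTT assay, with a stated time of 72 h; on this read-out lower numbers stand for stronger inhibition and higher numbers for weaker inhibition:
- compound 1 `COc1cc(-c2ncnn2-c2ccc(Cl)cc2Cl)cc(OC)c1OC`: > 10000 nM (a limit)
- compound 2 `COc1ccc(-c2ncnn2-c2cc(OC)c(OC)c(OC)c2)cc1`: 520 nM
- compound 3 `COc1cc(-c2ncnn2-c2ccc(N)cc2)cc(OC)c1OC`: > 10000 nM (a limit)

For the measured compounds named here, compound 2 holds the only numerical value in the set. The other two readings are limits: the limit of > 10000 nM in this assay, at which 2 of the 3 values shown sit.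

Compound 4 `COc1cc(-n2ncnc2-c2ccc(Cl)c(Cl)c2)cc(OC)c1OC` has 3,4-dichlorophenyl in place of the 4-methoxyphenyl of compound 2, on an aromatic carbon: 3,4-dichlorophenyl in place of 4-methoxyphenyl on an aromatic carbon.

Going by the values given here, the one measured step is a step that the two limits leave unreadable from compound 1 to compound 3. It runs between two limits and gives no size to carry over to this change. Among the compounds with values here, the only indirect hint comes from the one other dichlorophenyl compound, which holds that group on an aromatic nitrogen. Compound 1 reads > 10000 nM, which is a limit. This is weak support, but it points toward weaker inhibition, so a loss is expected in this assay rather than a gain. The expected step is a 4.8-fold higher number from compound 2 to compound 4 (0.68 log units; beyond the scatter), and its size is poorly constrained. For compound 4 the estimated value is 2500 nM, with an expected range of 500 nM to 10000 nM.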

Compound 4, half-maximal inhibitory concentration: > 10000 nM
Compound 4 ended at the assay's limit (the forecaster's own chance of this, stated with the estimate: 25%); middle value at least 4.0-fold (0.60 log units) away from the limit.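

In this assay, the aromatic carbon of the five-membered aromatic ring with 3 nitrogen gives the series its first readable step: 3,4-dichlorophenyl in place of 4-methoxyphenyl gives an at least 19-fold higher number from compound 2 to compound 4 (1.28 log units; beyond the scatter). The reading of compound 4, > 10000 nM, is a limit, so this size is only a minimum. The measurable activity of compound 2 is not kept after this one change, and compound 2 remains the only compound with a number: the limit of > 10000 nM in this assay, at which 3 of the 4 values shown sit.

The compounds shown leave open whether the loss goes with the two chlorine atoms or with the absence of the methoxy group, a question that 4-chlorophenyl or 4-ethoxyphenyl on this carbon would address. As far as these compounds go, how narrow the tolerance at this position is also stays open, and 4-hydroxyphenyl or unsubstituted phenyl there would test it.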